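From 2,5-difluorophenyl to 2,4-difluorophenyl on compound 1

The compounds below may be only part of what the source reports. "The series", "measured", "known", "first", "only" and "open" are said of these compounds alone.

In an ADME assay on Vero cells (Chlorocebus sabaeus) for cytotoxicity, read by crystal violet staining (on this read-out lower numbers stand for higher toxicity in this test and higher numbers for lower toxicity in this test), compound 1 `Fc1ccc(F)c(/N=N/c2ccc(NC[C@@H]3CCCN4CCCC[C@H]34)c3c2CCCC3)c1` gives 80000 nM. Compound 3 `Brc1cccc(/N=N/N2CCCCC2)c1` gives 85000 nM, which lies within the usual scatter of the value for compound 1. Compound 2 `c1ccc(/N=N/N2CCCCC2)cc1` reads > 100000 nM, and this is a limit of the test, not a number.

Compound 4 `Fc1ccc(/N=N/c2ccc(NC[C@@H]3CCCN4CCCC[C@H]34)c3c2CCCC3)c(F)c1` has the same atoms as compound 1, joined differently: 2,4-difluorophenyl in place of 2,5-difluorophenyl on a double-bonded nitrogen. Within the data shown here, no measured step covers this swap. Among the measured compounds shown here, the only step available, an at least 1.1-fold lower number from compound 2 to compound 3 (0.07 log units; that floor lies within the scatter), is a different change and lies within the scatter, so no step beyond the scatter is expected in this assay. The estimated step is no change at the digits printed from compound 1 to compound 4 (within the scatter). The expected value for compound 4 is 80000 nM, with an estimated range from 45000 nM to 100000 nM.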

Compound 4, half-maximal cytotoxic concentration: 15000 nM
For compound 4 the middle estimate is 5.3-fold (0.73 log units) above the measured one; measured number below the stated range.
By their numbers in this assay, from the lowest: compound 4; then compounds 1 and 3 (each within the scatter of the next). At a limit, above all of these: compound 2.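

In this assay the swap gives a 5.3-fold lower number from compound 1 to compound 4 (0.73 log units; beyond the scatter) and so higher toxicity in this test, although no atom is added or lost. The placing of the fluorines on this ring therefore counts, and this is the first step shown that lies beyond the scatter. No measurement shown here gives a reason for this step.

The compounds shown leave open how this ring behaves with a single fluorine, a methoxy group or an amine in place of the two fluorines. They also leave open whether 2,4-difluorophenyl has the same effect on another core.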